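Shifting the aryl group on an aminothiophene ketone core

The source may report more compounds than this note shows. Statements on the series, on what has been measured and on what is new or still open speak of the compounds shown alone.

Measured so far:
Compound 1, `COc1cc(C(=O)c2sc(-c3cc(OC)c(OC)c(OC)c3)cc2N)cc(OC)c1OC`: 840 nM
Compound 2, `COc1cc(C(=O)c2sc(-c3ccc([N+](=O)[O-])cc3)cc2N)cc(OC)c1OC`: 99 nM
Compound 3, `COc1cc(C(=O)c2sc(-c3ccc(-c4ccccc4)cc3)cc2N)cc(OC)c1OC`: > 10000 nM

All three share the same core and differ only in the aryl group attached to the ring carbon next to the sulfur. In a functional assay on CCRF-CEM cells (Homo sapiens) for antiproliferative activity (a lower number here means a stronger inhibitor, a higher number a weaker inhibitor), compound 2 gives 99 nM, the lowest of the two numbers reported. Compound 1, carrying the 3,4,5-trimethoxyphenyl group, gives 840 nM, a higher number. For compound 3 the result is only a limit, (the limit of > 10000 nM in this assay, at which 1 of the 3 values shown sits), so no number is known for it.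

Going by the values given here, the one step that can be measured here is an at least 100-fold higher number from compound 2 to compound 3 (2.00 log units; beyond the scatter); it shows that removing the nitro group in favour of a plain phenyl costs a great deal of activity.

Compound 4, `COc1cccc(-c2cc(N)c(C(=O)c3cc(OC)c(OC)c(OC)c3)s2)c1`, has not yet been measured. It differs from compound 2 as follows: 3-methoxyphenyl in place of 4-nitrophenyl on an aromatic carbon. The 3-methoxyphenyl group lacks the nitro group whose loss in the step to compound 3 was so costly, while compound 1 shows that methoxy groups on this ring still leave a measurable number. Compound 4 is therefore expected to fall between those two outcomes, with a step of a 15-fold higher number from compound 2 to compound 4 (1.18 log units; beyond the scatter) expected. The estimate for compound 4 is 1500 nM, with a range from 300 nM to 8000 nM.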

Compound 4, half-maximal inhibitory concentration: 16 nM
The estimate for compound 4 lay 94-fold (1.97 log units) above the measured number, outside the stated range (below it).
By their numbers in this assay, from the lowest: compound 4; then compound 2; then compound 1. At a limit, above all of these: compound 3.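

In this assay, the step to the 3-methoxyphenyl group, a 6.2-fold lower number from compound 2 to compound 4 (0.79 log units; beyond the scatter), shows that the 4-nitrophenyl group is not needed on this aromatic carbon next to the ring sulfur, and that a replacement carrying no nitro group can give a lower number. Compound 3 had left the nitro group looking essential, yet compound 4 gives 16 nM without it, so the large loss seen with the phenyl replacement cannot be read as a simple requirement for nitro on this aryl ring. The measurements shown offer no explanation for the gain from this exchange of groups.

The compounds shown leave open whether the gain in compound 4 depends on the methoxy group itself, a question that a hydroxyl or an ethoxy group in its place on the same aryl ring would help to answer. For compound 3 the value remains a limit rather than a number, so the full size of its loss stays unknown: the limit of > 10000 nM in this assay, at which 1 of the 4 values shown sits.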